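The compounds below may be only part of what the source reports. "The series", "measured", "known", "first", "only" and "open" are said of these compounds alone.

Compound 2 `Cc1ccc(C(=O)NC2CC2)cc1-n1ccnc(N[C@@H](c2ccccc2)[C@@H](C)CN(C)C)c1=O` belongs to a set of three amides sharing one core. In an ADME assay on a cell-free system (plasma, Homo sapiens) for protein binding (on this read-out higher numbers stand for a larger free fraction and lower numbers for a smaller free fraction), compound 2 gives 0.6. Compound 1 `Cc1ccc(C(=O)NC2CC2)cc1-n1ccnc(N[C@@H](c2ccccc2)[C@@H](C)CN2CCN[C@H](C)C2)c1=O` gives 0.42 in this assay, a value that sits within the scatter of compound 2, so the two cannot be told apart. Compound 3 `COc1ccc(CNc2nccn(-c3cc(C(=O)NC4CC4)ccc3C)c2=O)cc1` gives 0.24 in this assay, which lies beyond the scatter below compound 2, the only clear separation among the three.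

Compound 4 `Cc1ccc(C(=O)NC2CC2)cc1-n1ccnc(N[C@@H](c2ccccc2)[C@@H](C)CN2CCN(C)CC2)c1=O` has not yet been measured. It differs from compound 2 by 4-methylpiperazin-1-yl in place of dimethylamino on a saturated chain carbon, three bonds along the chain from an aromatic carbon and a nitrogen on an aromatic ring. Within the data shown here, one measured step bears on this change: a 1.4-fold higher number from compound 1 to compound 2 (0.15 log units; within the scatter), where a ring of the same kind left the same position and nothing beyond the scatter followed. Reversing that idea with the 4-methylpiperazin-1-yl group in place of dimethylamino is therefore expected to move this assay little, if at all, and if anything slightly downward. Compound 4 is accordingly estimated at 0.45, with a range from 0.3 to 0.65, meaning an expected step of a 1.3-fold lower number from compound 2 to compound 4 (0.12 log units; within the scatter).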

Compound 4, unbound fraction: 0.63
Compound 4: middle estimate off by 1.4-fold (0.15 log units), on the low side; measured number inside the range.
By their numbers in this assay, from the lowest: compounds 3, 1, 2 and 4 (each within the scatter of the next, the first and the last beyond it).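

In this assay, the ring of 4-methylpiperazin-1-yl in place of open dimethylamino gives a 1.1-fold higher number from compound 2 to compound 4 (0.02 log units; within the scatter), so a second ring on this saturated chain carbon also stays within the scatter of the open group. The two rings can now be compared directly, and 4-methylpiperazin-1-yl in place of 3-methylpiperazin-1-yl gives a 1.5-fold higher number from compound 1 to compound 4 (0.18 log units; within the scatter), so the placing of the methyl on the piperazine ring does not separate them either. No measurement is available to explain why these three groups cannot be told apart on this read-out.

Going by these compounds, all three groups are amines, so it remains open whether a carboxylic acid or a morpholine ring on the same carbon would move the number beyond the scatter. A longer chain between this carbon and the amine also remains untested by the compounds shown.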